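The compounds below may be only part of what the source reports. "The series", "measured", "known", "first", "only" and "open" are said of these compounds alone.

Measured compounds and their numbers:

compound 1 `COc1cc(OC)c(OC)cc1/C=C/C(=O)c1ccc(C)cc1` — 2.18 ug/mL
compound 2 `COc1cc(OC)c(OC)cc1/C=C/C(=O)c1ccc(O)cc1O` — 2.76 ug/mL
compound 3 `COc1cc(OC)c(OC)cc1/C=C/C(=O)c1ccc([N+](=O)[O-])cc1` — 1.98 ug/mL

In a functional assay, read by Griess assay, with a stated time of 2.5 h (on this read-out lower numbers stand for stronger inhibition and higher numbers for weaker inhibition), compound 3 gives the lowest of the three numbers, but its gaps to compound 1 and to compound 2 both fall within the scatter, so the three compounds cannot be told apart on this read-out. Compound 4 `COc1ccc(C(=O)/C=C/c2cc(OC)c(OC)cc2OC)cc1` differs from compound 3 by methoxy in place of nitro on an aromatic carbon. For the measured compounds named here, two measured steps bear on this change, both altering the same ring: a 1.1-fold lower number from compound 1 to compound 3 (0.04 log units; within the scatter) and a 1.3-fold higher number from compound 1 to compound 2 (0.10 log units; within the scatter). Neither moved the number beyond the scatter. On that evidence a step of a 1.2-fold higher number from compound 3 to compound 4 (0.07 log units; within the scatter) is expected, with no change beyond the scatter in either direction. Compound 4 is therefore estimated at 2.3 ug/mL, with a range from 1.2 ug/mL to 4.6 ug/mL.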

Compound 4, half-maximal inhibitory concentration: 2.07 ug/mL
Beside the measured number, compound 4's estimate is 1.1-fold (0.05 log units) above it, within the range that was stated.
By their numbers in this assay, from the lowest: compounds 3, 4, 1 and 2 (each within the scatter of the next).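

In this assay, methoxy on this aromatic carbon, para to a large group, stays within the scatter of nitro (a 1.0-fold higher number from compound 3 to compound 4 (0.02 log units; within the scatter)) and of methyl (a 1.1-fold lower number from compound 1 to compound 4 (0.02 log units; within the scatter)), and 4-methoxyphenyl stays within the scatter of 2,4-dihydroxyphenyl (a 1.3-fold lower number from compound 2 to compound 4 (0.12 log units; within the scatter)). The four compounds therefore cannot be told apart on this read-out, and methoxy adds no exception. Nothing available here accounts for this result. From the compounds shown here alone, whether an amine or a carboxylic acid on this carbon would move the number beyond the scatter remains open, as does the effect of a longer chain there.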